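A few compounds are considered here, and "the series" means these few. Any claim that something is new, unique, unknown or untested is made for them only; others in the source may bear on it.

Compound 1 `O=C(NNc1ccccc1)C1CCC(=O)N1S(=O)(=O)c1ccc(Cl)cc1` and compound 2 `O=C(NNc1ccccc1)C1CCC(=O)N1S(=O)(=O)c1ccc(Cl)c(Cl)c1` have both been tested in a functional assay on the whole organism with Mus musculus as the target, at a dose of 50 mg/kg by the intraperitoneal route; on this read-out lower numbers stand for less inhibition and higher numbers for more inhibition at the one dose given (going by the name of the read-out). Compound 1 gives 71.4%, while compound 2 gives 57.7%, the lower of the two numbers. Within the data shown here, the one comparison available, a number 13.7 percentage points lower from compound 1 to compound 2 (beyond the scatter), came with chloro in place of hydrogen on an aromatic carbon. Compound 3 `O=C(NNc1ccccc1)C1CCC(=O)N1S(=O)(=O)c1ccccc1` has not yet been measured; it differs from compound 2 by phenyl in place of 3,4-dichlorophenyl on a sulfonyl sulfur. Only the removal of one chloro has been observed, and removing both goes a step further, so compound 3 is expected to rise by roughly a number 14.3 percentage points higher from compound 2 to compound 3 (beyond the scatter). The estimate for compound 3 is therefore 72%, with a range from 52% to 88%.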

Compound 3, a percentage reported as inhibition, in the whole organism at one dose (the size of the read-out at that dose, not a potency): 85.7%
Compound 3: middle estimate off by 13.7 percentage points, on the low side; the range from low to high includes it.
By their numbers in this assay, from the lowest: compound 2; then compound 1; then compound 3.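

In this assay, the full change to phenyl on the sulfonyl sulfur gives a number 28 percentage points higher from compound 2 to compound 3 (beyond the scatter) and leaves compound 3 highest of the three. The earlier pair showed only that a second chloro goes with a lower number, whereas a number 14.3 percentage points higher from compound 1 to compound 3 (beyond the scatter) shows that removing the last chloro also goes with a higher one. Nothing measured here explains this trend.

From the compounds shown here alone, whether hydrogen is the best choice on this ring remains open. A methoxy group or an amine in place of chloro could read higher or lower.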